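This account rests on a few compounds, and the source may have more. Where it says the series, first, only, none or still open, it means among the compounds named here.

In a functional assay on MHCC97H cells (Homo sapiens) for antiproliferative activity, read by MTT assay, with a stated time of 48 h (on this read-out higher numbers stand for weaker inhibition and lower numbers for stronger inhibition), compound 2 `COc1cc(C(=O)/C=C/c2cn(C)c3ccccc23)cc(N)c1OC` gives 289 nM, the highest of the three numbers in hand. Compound 1 `COc1ccc2c(/C=C/C(=O)c3cc(N)c(OC)c(OC)c3)cn(C)c2c1` gives 198 nM, and the step of a 1.5-fold higher number from compound 1 to compound 2 (0.16 log units; within the scatter) arises from hydrogen in place of methoxy on an aromatic carbon. Compound 3 `COc1ccc2c(/C=C(\C)C(=O)c3cc(OC)c(OC)c([Se]C)c3)c[nH]c2c1` gives 6 nM, well below compound 2; it differs from compound 2 in several places at once, so its gap cannot be tied to any single change. Compound 4 `COc1cc(C(=O)/C=C/c2cn(C)c3ccccc23)cc([N+](=O)[O-])c1OC` has not yet been measured; it differs from compound 2 by nitro in place of amino on an aromatic carbon. Going by the values given here, no measured step exchanges an amino for a nitro, and the one step in hand concerns a methoxy elsewhere, so nothing among the measured compounds speaks directly to this change. The expected step of a 1.4-fold higher number from compound 2 to compound 4 (0.14 log units; within the scatter) is therefore set at none beyond the scatter, with a wide range around it. For compound 4 the estimate in this assay is 400 nM, between 150 nM and 1500 nM.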

Compound 4, half-maximal inhibitory concentration: 850 nM
Compound 4: the middle estimate sits 2.1-fold (0.33 log units) below what was measured; measured number inside the range.
By their numbers in this assay, from the lowest: compound 3; then compounds 1 and 2 (each within the scatter of the next); then compound 4.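

In this assay, going by these compounds alone, nitro in place of amino on this aromatic carbon, ortho to a methoxy group, gives (a 2.9-fold higher number from compound 2 to compound 4 (0.47 log units; beyond the scatter)), a modest change but the first step here to lie beyond the scatter. The number therefore responds to the group held at this position, unlike the step at a methoxy elsewhere on the core (a 1.5-fold higher number from compound 1 to compound 2 (0.16 log units; within the scatter)), which stayed within the scatter. No measurement given here accounts for the size or direction of the amino-to-nitro step.

Still open, on these data alone, is how a hydroxyl, an acetamide or a methylamino group at this same position would compare with amino and nitro. As far as these compounds go, it is also open whether nitro in place of amino would give a similar step on the core of compound 1 , which carries the extra methoxy.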